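Fluoro to chloro on one aromatic carbon

A few compounds are considered here, and "the series" means these few. Any claim that something is new, unique, unknown or untested is made for them only; others in the source may bear on it.

Compound 1 `Cc1nn(-c2ccccn2)c2cc(-c3ccc(CCC(=O)O)cc3C#N)ccc12` and compound 2 `Cc1nn(-c2ccccn2)c2cc(-c3ccc(CCC(=O)O)cc3F)ccc12` share the same core and differ on one aromatic carbon. Within the data shown here, in a physicochemical assay for lipophilicity, using the shake flask method, measured as octanol-water partition, with a stated time of 30 min, at pH 7.4 (on this read-out higher numbers stand for higher lipophilicity and lower numbers for lower lipophilicity), compound 1 gives 2.2 and compound 2 gives 2.9, the higher of the two numbers so far. Compound 3 `Cc1nn(-c2ccccn2)c2cc(-c3ccc(CCC(=O)O)cc3Cl)ccc12` alters that same carbon again: chloro in place of fluoro on an aromatic carbon, ortho to a large group. Among the measured compounds shown here, only one measured step bears on this change, a number 0.70 log units higher from compound 1 to compound 2 (beyond the scatter), which came with fluoro in place of cyano. That step involves a different pair of groups, so it is only a loose guide, and nothing yet measured shows chloro itself. A smaller upward move in this assay is expected, with the estimated step being a number 0.40 log units higher from compound 2 to compound 3 (beyond the scatter). Compound 3 is therefore expected to read 3.3, within an estimated range of 2.9 to 3.7.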

Compound 3, distribution coefficient: 3.3
The estimate for compound 3 equals the measured number at the digits printed, within the range that was stated.
By their numbers in this assay, from the lowest: compound 1; then compound 2; then compound 3.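

With chloro on this carbon, this assay shows a number 0.40 log units higher from compound 2 to compound 3 (beyond the scatter) and so separates two halogens at this position, where the earlier pair compared only fluoro with cyano. Among these compounds, measured against cyano, chloro gives a number 1.10 log units higher from compound 1 to compound 3 (beyond the scatter) and this is the largest of the steps so far, which puts the three groups in the order cyano, fluoro, chloro from the lowest number to the highest while the rest of the structure stays the same. No measurement available here explains why the number moves with these groups.

The compounds shown leave open where a methyl, a methoxy or an amine on this carbon would fall in that order. They also leave open whether the same swap would give a step of similar size with a longer chain in place of the 2-carboxyethyl group.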